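Ester variation on the core and metabolic stability

A few compounds are considered here, and "the series" means these few. Any claim that something is new, unique, unknown or untested is made for them only; others in the source may bear on it.

Compound 1 `CCCCCOC(=O)Cc1c(C(C)C)nc(CCCC)n(Cc2ccc(-c3ccccc3-c3noc(=O)[nH]3)cc2)c1=O`: 19.7%
Compound 2 `CCCCc1nc(C(C)C)c(CC(=O)OC2CC2)c(=O)n1Cc1ccc(-c2ccccc2-c2noc(=O)[nH]2)cc1`: 11.4%
Compound 3 `CCCCc1nc(C(C)C)c(CC(=O)OC(CC)CC)c(=O)n1Cc1ccc(-c2ccccc2-c2noc(=O)[nH]2)cc1`: 14.6%

Three compounds sharing one core and differing only in the group on the oxygen next to a carbonyl group were tested in an ADME assay on microsomes from liver (Mus musculus) for metabolic stability, with a stated time of 30 min; on this read-out higher numbers stand for a more stable compound and lower numbers for a less stable compound. Compound 1 gives 19.7%, compound 2 gives 11.4% and compound 3 gives 14.6%. Compound 3 holds the second highest of the three numbers, with compound 2 nearest and compound 1 furthest, and every gap among them lies within the scatter: a number 8.3 percentage points lower from compound 1 to compound 2 (within the scatter), a number 5.1 percentage points lower from compound 1 to compound 3 (within the scatter) and a number 3.2 percentage points higher from compound 2 to compound 3 (within the scatter).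

The next compound, compound 4 `CC#CCOC(=O)Cc1c(C(C)C)nc(CCCC)n(Cc2ccc(-c3ccccc3-c3noc(=O)[nH]3)cc2)c1=O`, carries a further exchange at the same place: but-2-yn-1-yl in place of pentan-3-yl on an oxygen next to a carbonyl group. All three measured steps at this oxygen bear on it, and none of them moved this assay beyond the scatter, whether a chain was shortened, branched or closed into a ring. On that footing, compound 4 is expected to sit close to compound 3, and the step of a number 0.4 percentage points higher from compound 3 to compound 4 (within the scatter) is estimated to stay within the scatter. The expected value for compound 4 in this assay is 15%, with a range from 6% to 28%.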

Compound 4, percent of the compound remaining: 16.4%
The estimate for compound 4 lay 1.4 percentage points below the measured number; the range from low to high includes it.
By their numbers in this assay, from the lowest: compounds 2, 3, 4 and 1 (each within the scatter of the next).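

With but-2-yn-1-yl, a group with a triple bond outside aromatic rings now stands on the oxygen next to a carbonyl group, and this assay still shows no separation from the groups with no such bond: the exchange for pentan-3-yl gives a number 1.8 percentage points higher from compound 3 to compound 4 (within the scatter) and the exchange for cyclopropyl gives a number 5 percentage points higher from compound 2 to compound 4 (within the scatter). Read on a saturated chain carbon bound to that oxygen, prop-1-yn-1-yl in place of butyl gives a number 3.3 percentage points lower from compound 1 to compound 4 (within the scatter), so the triple bond also leaves the number within the scatter when compared with the straight pentyl chain. The four compounds therefore form a single group at this position, with no step among them beyond the scatter, and nothing at hand explains this result.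

From the compounds shown here alone, all four groups on this oxygen consist of carbon and hydrogen only, so it remains open whether a chain carrying an amine, a trifluoromethyl group or a free carboxylic acid in place of the ester would move this assay beyond the scatter. Going by these compounds, it is also open whether these exchanges would stay equally silent with a different group in place of the butyl chain on the shared core.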